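Bromo in Place of Methoxy: Compound 3 Awaits Measurement

A few compounds are considered here, and "the series" means these few. Any claim that something is new, unique, unknown or untested is made for them only; others in the source may bear on it.

In a functional assay on HCT-116 cells (Homo sapiens) for inhibition, read by MTT assay, with a stated time of 48 h (a higher number here means a weaker inhibitor, a lower number a stronger inhibitor), two compounds have been measured so far. Compound 1 (`Cc1ccc(/C=C2\SC(=O)N(CCNC(=O)Nc3c(C)n(C)n(-c4ccccc4)c3=O)C2=O)cc1`) gives 32700 nM, and compound 2 (`COc1ccc(/C=C2\SC(=O)N(CC(=O)Nc3c(C)n(C)n(-c4ccccc4)c3=O)C2=O)cc1`) gives 70300 nM, the higher of the two numbers and a gap beyond the usual scatter. These two compounds differ in more than one place, so their gap cannot be assigned to any single change. The next compound, compound 3 (`Cc1c(NC(=O)CN2C(=O)S/C(=C\c3ccc(Br)cc3)C2=O)c(=O)n(-c2ccccc2)n1C`), keeps the rest of compound 2 but carries bromo in place of methoxy on an aromatic carbon, para to a large group (bromo in place of methoxy on an aromatic carbon). Among the measured compounds shown here, no measured pair isolates this change, which leaves its effect in this assay without a direct precedent. Only a slight shift towards a lower number, within the scatter, is expected, with an estimated 1.6-fold lower number from compound 2 to compound 3 (0.19 log units; within the scatter). For compound 3 the expected value is 45000 nM, with an estimated range of 18000 nM to 100000 nM.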

Compound 3, half-maximal inhibitory concentration: 7840 nM
Compound 3: middle estimate off by 5.7-fold (0.76 log units), on the high side; measured number below the stated range.
By their numbers in this assay, from the lowest: compound 3; then compound 1; then compound 2.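

In this assay the change from 4-methoxyphenyl to 4-bromophenyl gives a 9.0-fold lower number from compound 2 to compound 3 (0.95 log units; beyond the scatter) and lies beyond the scatter, showing that the group on this aromatic carbon, para to a large group, can alter the read-out while the rest of the structure stays fixed. The earlier compounds shown here could not show this, since they differ in more than one place and no single change could be read from them. The compounds shown offer no measured information that explains why bromo gives the lower number here.

As far as these compounds go, it remains open whether chloro, fluoro, an amine or a carboxylic acid at this same position would go with a lower or a higher number than bromo. From the compounds shown here alone, it also remains open whether bromo in place of methoxy would give a step of similar size on the chain carried by compound 1.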